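The compounds below may be only part of what the source reports. "The series", "measured", "known", "first", "only" and "open" are said of these compounds alone.

Measured in a functional assay on MCF7 cells (Homo sapiens) for cytotoxicity; a lower number here means a stronger inhibitor, a higher number a weaker inhibitor:
- compound 1 `C=C/C=C\[C@H](C)[C@H](OC(N)=O)[C@@H](C)[C@H](O)[C@@H](C)C/C(C)=C\[C@H](C)[C@@H](O)[C@@H](C)/C=C\CCc1ccc(Oc2ccccc2)cc1`: 10000 nM
- compound 2 `C=C/C=C\[C@H](C)[C@H](OC(N)=O)[C@@H](C)[C@H](O)[C@@H](C)C/C(C)=C\[C@H](C)[C@@H](O)[C@@H](C)/C=C\CCc1cccc(F)c1`: 500 nM
- compound 3 `C=C/C=C\[C@H](C)[C@H](OC(N)=O)[C@@H](C)[C@H](O)[C@@H](C)C/C(C)=C\[C@H](C)[C@@H](O)[C@@H](C)/C=C\CCc1cccc(O)c1C`: 1000 nM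

In this assay, compound 3 lies within the scatter of compound 2, and its number is clearly lower than that of compound 1. The next compound is compound 4 `C=C/C=C\[C@H](C)[C@H](OC(N)=O)[C@@H](C)[C@H](O)[C@@H](C)C/C(C)=C\[C@H](C)[C@@H](O)[C@@H](C)/C=C\CCc1sccc1C`, where 3-methylthiophen-2-yl stands in place of 3-hydroxy-2-methylphenyl on a saturated chain carbon: 3-methylthiophen-2-yl in place of 3-hydroxy-2-methylphenyl on a saturated chain carbon, two bonds along the chain from a double-bonded chain carbon. Among the compounds with values here, only one measured step bears directly on this position, a 2.0-fold higher number from compound 2 to compound 3 (0.30 log units; within the scatter), and it stays within the scatter. Within the data shown here, no measured compound carries a five-membered aromatic ring, so the new ring remains untested. The high number of compound 1, 10000 nM, shows that a change in this group can matter, so the range is kept wide. No step beyond the scatter is therefore expected in this assay. The expected step is a 1.3-fold lower number from compound 3 to compound 4 (0.10 log units; within the scatter). For compound 4 the estimated value is 800 nM, with an expected range from 250 nM to 3000 nM.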

Compound 4, half-maximal inhibitory concentration: 620 nM
For compound 4 the middle estimate is 1.3-fold (0.11 log units) above the measured one; measured number inside the range.
By their numbers in this assay, from the lowest: compounds 2, 4 and 3 (each within the scatter of the next); then compound 1.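

In this assay the exchange of the six-membered aromatic ring for a five-membered one gives a 1.6-fold lower number from compound 3 to compound 4 (0.21 log units; within the scatter) and stays equally small against the fluorinated ring, with a 1.2-fold higher number from compound 2 to compound 4 (0.09 log units; within the scatter) as the printed step. So this place, on a saturated chain carbon, two bonds along the chain from a double-bonded chain carbon, accepts 3-methylthiophen-2-yl, a ring with a sulfur atom and no hydrogen-bond donor, with no step beyond the scatter against either 3-hydroxy-2-methylphenyl or 3-fluorophenyl. No evidence is available that would account for this result.

From the compounds shown here alone, it remains open whether the methyl group of 3-methylthiophen-2-yl contributes anything, and whether an amine or a carboxylic acid on the ring would keep the number within this group. Going by these compounds, a longer chain between the double bond and the ring is equally open.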